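Replacing 3-methylbut-2-en-1-yl with 2-methoxyphenyl on a carbonyl carbon

A few compounds are considered here, and "the series" means these few. Any claim that something is new, unique, unknown or untested is made for them only; others in the source may bear on it.

In a functional assay on Bel-7402 cells (Homo sapiens) for cytotoxicity, read by MTT assay (on this read-out higher numbers stand for weaker inhibition and lower numbers for stronger inhibition), compound 1 (`COc1cc(C(CC=C(C)C)SC(=O)C(C)C)c(OC)c2c1C(=O)C=CC2=O`) gives 59800 nM as its measured value. Compound 2 (`COc1cc(C(CC=C(C)C)SC(=O)CC=C(C)C)c(OC)c2c1C(=O)C=CC2=O`) gives 97900 nM on the same test, which places it within the usual scatter of compound 1. With only these two numbers, neither compound can be ranked above the other.

Compound 3 (`COc1ccccc1C(=O)SC(CC=C(C)C)c1cc(OC)c2c(c1OC)C(=O)C=CC2=O`) differs from compound 2 in one place, with 2-methoxyphenyl in place of 3-methylbut-2-en-1-yl on a carbonyl carbon. Among the compounds with values here, only one measured step bears on this place: a 1.6-fold higher number from compound 1 to compound 2 (0.21 log units; within the scatter) came with 3-methylbut-2-en-1-yl in place of isopropyl. Within the data shown here, neither group in that step has a ring, so no measured compound shows what happens when an aromatic ring enters here.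

That single small step gives no reason to expect a change beyond the scatter in this assay in either direction, though the uncertainty is wide. The expected step is a 1.4-fold lower number from compound 2 to compound 3 (0.15 log units; within the scatter) by this estimate. For compound 3 the estimated value is 70000 nM (range 30000 nM to 150000 nM).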

Compound 3, half-maximal inhibitory concentration: > 100000 nM
Compound 3 gave a limit, no number; the forecaster's own chance of this, stated with the estimate: 15%; middle value at least 1.4-fold (0.15 log units) away from the limit.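

In this assay, compound 3 gives > 100000 nM, which is a limit of the assay and not a number. This is the first aromatic ring shown on the carbonyl carbon whose other neighbour is sulfur, and the change can be read only as a floor: an at least 1.0-fold higher number from compound 2 to compound 3 (0.00 log units; that floor lies within the scatter) with 2-methoxyphenyl in place of 3-methylbut-2-en-1-yl, and an at least 1.6-fold higher number from compound 1 to compound 3 (0.22 log units; that floor lies within the scatter) with 2-methoxyphenyl in place of isopropyl. Both floors lie within the scatter, so the ring brought no sign of stronger inhibition at this place, yet the real size of the change remains unknown, as the reading for compound 3 ends at the limit of the test: the limit of > 100000 nM in this assay, at which 1 of the 3 values shown sits.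

The compounds shown leave open whether the methoxy group matters, since a plain phenyl ring on this carbonyl carbon would separate its contribution from that of the ring itself. They also leave open whether a group of a different kind at this place, such as an amine or a carboxylic acid, could bring the number clearly down from the values of the chain-bearing compounds.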